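Shifting the Methyl on the Phenoxy Ring

The compounds below may be only part of what the source reports. "The series", "measured", "known", "first", "only" and "open" are said of these compounds alone.

Of the compounds shown here, three have been measured in a functional assay on A549 cells (Homo sapiens) for cytotoxicity, read by MTT assay, with a stated time of 48 h; a higher number here means a weaker inhibitor, a lower number a stronger inhibitor: compound 1 `Cc1ccc(-c2csc(NC(=O)COc3ccccc3C)n2)cc1` gives 50900 nM; compound 2 `Cc1ccccc1OCC(=O)Nc1nc(-c2ccc(Cl)cc2)cs1` gives 64900 nM; compound 3 `CC(C)c1ccccc1OCC(=O)Nc1nc(-c2ccc(Cl)cc2)cs1` gives 17800 nM.

Of these numbers, that of compound 2 is the largest, though the step of a 1.3-fold higher number from compound 1 to compound 2 (0.11 log units; within the scatter) lies within the scatter, whereas the step of a 3.6-fold lower number from compound 2 to compound 3 (0.56 log units; beyond the scatter) lies beyond it. Compound 4 `Cc1ccc(OCC(=O)Nc2nc(-c3ccc(Cl)cc3)cs2)cc1` differs from compound 2 by 4-methylphenyl in place of 2-methylphenyl on an oxygen on a saturated carbon. Neither measured step bears directly on this change: both swap one group for another while the methyl on the phenoxy ring stays where it is. Nothing in the data speaks for a shift in either direction, so the step of a 1.1-fold lower number from compound 2 to compound 4 (0.03 log units; within the scatter) is expected to stay within the scatter. Compound 4 is therefore estimated at 60000 nM, with a range from 20000 nM to 150000 nM.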

Compound 4, half-maximal inhibitory concentration: 45700 nM
Compound 4: the middle estimate sits 1.3-fold (0.12 log units) above what was measured; the measured number falls inside the stated range.
By their numbers in this assay, from the lowest: compound 3; then compounds 4, 1 and 2 (each within the scatter of the next).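

Moving the methyl, with 4-methylphenyl in place of 2-methylphenyl, is the first change shown that keeps the same atoms and alters only how they are joined, and in this assay it gives a 1.4-fold lower number from compound 2 to compound 4 (0.15 log units; within the scatter). The earlier steps shown here changed the group itself, whereas this one shows that the two placements of the methyl cannot be told apart in this assay. Nothing measured here accounts for this result.

The compounds shown leave open whether an amine or a carboxylic acid in place of the methyl on the phenoxy ring would leave the number equally unmoved. They also leave open whether the isopropyl of compound 3 would keep its effect if shifted in the same way.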